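Swapping the ring on the amide-type nitrogen

A few compounds are considered here, and "the series" means these few. Any claim that something is new, unique, unknown or untested is made for them only; others in the source may bear on it.

Of the compounds shown here, two built on one shared core have been measured in an assay on isolated protein for inhibition of phosphodiesterase 4A (Sus scrofa); a lower number here means a stronger inhibitor, a higher number a weaker inhibitor. Compound 1 `COc1ccc(C(=O)Nc2ccccc2C)cc1OC1CCCC1` gives 300 nM in this assay. Compound 2 `COc1ccc(C(=O)Nc2ccncc2Cl)cc1OC1CCCC1` gives 16 nM in this assay. The only difference between them is the ring attached to the amide-type nitrogen, and the step of a 19-fold lower number from compound 1 to compound 2 (1.27 log units; beyond the scatter) shows how strongly that one exchange moved the number. Of the two values measured, compound 2 has the lower one, and compound 1, the nearest, lies well beyond the scatter above it.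

Compound 3 `COc1ccc(C(=O)Nc2c(C)nsc2C#N)cc1OC1CCCC1` has not yet been measured. It differs from compound 2 at the same place: 5-cyano-3-methyl-1,2-thiazol-4-yl in place of 3-chloropyridin-4-yl on an amide-type nitrogen. For the measured compounds named here, the one measured step that bears on this change is the large one from compound 1 to compound 2, which replaced a ring without hetero atoms by one carrying a hetero atom. Here one ring with hetero atoms replaces another, so a shift of that size seems less likely. The step of a 1.6-fold higher number from compound 2 to compound 3 (0.19 log units; within the scatter) is therefore expected to be modest. Compound 3 is expected to give 25 nM in this assay, with a likely range from 6 nM to 100 nM.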

Compound 3, half-maximal inhibitory concentration: 200 nM
Compound 3: the middle estimate sits 8.0-fold (0.90 log units) below what was measured; the whole stated range lies below it.
By their numbers in this assay, from the lowest: compound 2; then compounds 3 and 1 (each within the scatter of the next).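

At this position, a ring with hetero atoms does not by itself keep the number low: in this assay, replacing one such ring with another gives a large step (a 13-fold higher number from compound 2 to compound 3 (1.10 log units; beyond the scatter)). The 5-cyano-3-methyl-1,2-thiazol-4-yl group also cannot be told apart from the 2-methylphenyl group, which has no hetero atoms (a 1.5-fold lower number from compound 1 to compound 3 (0.18 log units; within the scatter)), so among these three rings only the 3-chloropyridin-4-yl group of compound 2 stands apart. Nothing in the data given explains why these exchanges move the number as they do.

The entering and leaving rings differ in several features at once, including ring size, the sulfur atom, the nitrile and the chlorine, so the compounds shown cannot separate the contribution of any single feature. Also open, from the compounds shown here alone, is how the number would respond to a plain pyridin-4-yl group, or to a 3-methylpyridin-4-yl group, where a methyl group takes the place of the chlorine on the same ring.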